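Sulfonyl substituent change in an indole series for receptor binding

This account rests on a few compounds, and the source may have more. Where it says the series, first, only, none or still open, it means among the compounds named here.

Measured so far:
compound 1 `CN1CCN(c2ccc3ccn(S(=O)(=O)c4ccccc4)c3c2)CC1` — 9 nM
compound 2 `O=S(=O)(c1ccccc1)n1ccc2ccc(-c3ccccc3)cc21` — 178 nM
compound 3 `O=S(=O)(c1ccccc1)n1ccc2ccc(-c3ccncc3)cc21` — 38 nM

In an assay on isolated protein for displacement of a labelled ligand from 5-hydroxytryptamine receptor 6 (Homo sapiens), read by scintillation counting, with a stated time of 1 h (on this read-out higher numbers stand for weaker inhibition and lower numbers for stronger inhibition), compound 3 stands second of the three numbers; it lies between compound 1 (a 4.2-fold higher number from compound 1 to compound 3 (0.63 log units; beyond the scatter)) and compound 2 (a 4.7-fold lower number from compound 2 to compound 3 (0.67 log units; beyond the scatter)). Compound 4 `O=S(=O)(C1CCCCC1)n1ccc2ccc(-c3ccncc3)cc21` differs from compound 3 by cyclohexyl in place of phenyl on a sulfonyl sulfur. Every measured step (a 20-fold higher number from compound 1 to compound 2 (1.30 log units; beyond the scatter), a 4.2-fold higher number from compound 1 to compound 3 (0.63 log units; beyond the scatter), a 4.7-fold lower number from compound 2 to compound 3 (0.67 log units; beyond the scatter)) changes the group on the aromatic carbon, not the group on the sulfonyl sulfur; none of them bears on this change. The shared core and its pyridin-4-yl group are kept, so no step beyond the scatter is firmly expected, though the direction is open. Compound 4 is expected at 90 nM, range 25 nM to 350 nM, a step of a 2.4-fold higher number from compound 3 to compound 4 (0.37 log units; beyond the scatter) from compound 3.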

Compound 4, inhibition constant: 2180 nM
Compound 4: the middle estimate sits 24-fold (1.38 log units) below what was measured, outside the stated range (above it).
By their numbers in this assay, from the lowest: compound 1; then compound 3; then compound 2; then compound 4.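

With the shared core and the pyridin-4-yl group kept, cyclohexyl in place of phenyl on the sulfonyl sulfur gives a 57-fold higher number from compound 3 to compound 4 (1.76 log units; beyond the scatter) in this assay, so the group at this position strongly affects the binding number. Phenyl and cyclohexyl match in heavy atoms and differ in whether the six-membered ring is aromatic, and in this single pair the aromatic ring gives the lower number. Nothing available accounts for the size of this step.

On these data alone, whether a pyridin-3-yl or a methyl group on the sulfonyl sulfur would keep the lower number remains open. Also open, as far as these compounds go, is whether cyclohexyl has a similar effect with 4-methylpiperazin-1-yl on the aromatic carbon.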